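The source may hold more compounds than are shown below. What is called first, only, known or untested is meant among the compounds shown, and "the series" means these compounds.

Compound 1 `Cc1noc(C)c1-c1ccc2c(c1)C(c1ccccc1)N(Cc1ncc(-c3ccccc3)o1)C(=O)N2C`: 30%
Compound 2 `Cc1noc(C)c1-c1ccc2c(c1)C(c1ccccc1)N(Cc1nnc(-c3ccccc3)s1)C(=O)N2C`: 26.9%
Compound 3 `Cc1noc(C)c1-c1ccc2c(c1)C(c1ccccc1)N(Cc1csc(-c3ccc(F)cc3)n1)C(=O)N2C`: 31.8%

In a functional assay on HCT-116 cells (Homo sapiens) for inhibition, read by MTT assay, with a stated time of 48 h, tested at 2 uM (a higher number here means more inhibition at the concentration tested (going by the name of the read-out), a lower number less inhibition), compound 3 gives the highest of the three numbers, but only within the scatter: the nearest measured step is a number 1.8 percentage points higher from compound 1 to compound 3 (within the scatter) and the furthest is a number 4.9 percentage points higher from compound 2 to compound 3 (within the scatter). Compound 4 `Cc1noc(C)c1-c1ccc2c(c1)C(c1ccccc1)N(Cc1nnc(-c3ccc(F)cc3)o1)C(=O)N2C` differs from compound 3 by 5-(4-fluorophenyl)-1,3,4-oxadiazol-2-yl in place of 2-(4-fluorophenyl)-1,3-thiazol-4-yl on a saturated chain carbon bound to an amide-type nitrogen in a ring. Among the measured compounds shown here, every measured step so far swaps one five-membered aromatic ring for another at this same place, and none moved the read-out beyond the scatter: a number 3.1 percentage points lower from compound 1 to compound 2 (within the scatter), a number 1.8 percentage points higher from compound 1 to compound 3 (within the scatter) and a number 4.9 percentage points higher from compound 2 to compound 3 (within the scatter). A further swap of this kind is therefore expected to give no step beyond the scatter, estimated as a number 1.8 percentage points lower from compound 3 to compound 4 (within the scatter). Compound 4 is expected to give about 30%, with a range from 18% to 42%.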

Compound 4, a percentage reported as inhibition, at one concentration (the size of the read-out at that concentration, not a potency): 36.6%
Compound 4: the middle estimate sits 6.6 percentage points below what was measured; the range from low to high includes it.
By their numbers in this assay, from the lowest: compounds 2, 1, 3 and 4 (each within the scatter of the next).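

A fourth five-membered aromatic ring, now the 5-(4-fluorophenyl)-1,3,4-oxadiazol-2-yl group with its three hetero atoms, still leaves this assay within the scatter at this place (a number 4.8 percentage points higher from compound 3 to compound 4 (within the scatter); a number 9.7 percentage points higher from compound 2 to compound 4 (within the scatter); a number 6.6 percentage points higher from compound 1 to compound 4 (within the scatter)). Even the step from the thiadiazole, where the ring changes and a fluorine is added, stays within the scatter. No measurement shown here bears on why these numbers come out as they do. Still open, as far as these compounds go, is whether an amine or a carboxylic acid in place of the aromatic rings would move the read-out beyond the scatter.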